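The source may hold more compounds than are shown below. What is called first, only, known or untested is meant among the compounds shown, and "the series" means these compounds.

Measured so far:
Compound 1 `NC(=S)N/N=C/c1ccc2ccccc2n1` gives 32700 nM in a functional assay on SGC-7901 cells (Homo sapiens) for antiproliferative activity, read by sulforhodamine B assay, with a stated time of 72 h; a higher number here means a weaker inhibitor, a lower number a stronger inhibitor.
Compound 2 `COc1ccc(C)cc1NC(=S)N/N=C/c1ccc2ccccc2n1` reaches only a limit, > 100000 nM, in this assay and so gives no number.
Compound 3 `NC(=S)N/N=C/c1cc2ccccc2s1` likewise reaches only a limit, > 100000 nM, in this assay.

Among the compounds with values here, compound 1 therefore holds the only numerical value in this assay; the other two results sit at the limit of > 100000 nM in this assay, at which 2 of the 3 values shown sit. Compound 4 `S=C(NCc1ccccc1)N/N=C/c1ccc2ccccc2n1` has not yet been measured in this assay. It differs from compound 1 in one place: benzyl in place of hydrogen on an amide-type nitrogen. Within the data shown here, no step between two measured compounds is available to guide the direction. Given that compound 2 sits at the limit of > 100000 nM in this assay, at which 2 of the 3 values shown sit, a modest weakening is expected in this assay, though it may remain within the scatter. Compound 4 is estimated at 60000 nM, with a range from 20000 nM to 200000 nM, which means an expected step of a 1.8-fold higher number from compound 1 to compound 4 (0.26 log units; within the scatter).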

Compound 4, half-maximal inhibitory concentration: 53700 nM
Estimate against measurement, compound 4: 1.1-fold (0.05 log units) above, within the range that was stated.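

Benzyl in place of hydrogen on the amide-type nitrogen gives no change beyond the scatter in this assay (a 1.6-fold higher number from compound 1 to compound 4 (0.22 log units; within the scatter)). That nitrogen therefore need not carry its hydrogen for the activity of compound 1 to persist, and benzyl does not put compound 4 at the limit: (the limit of > 100000 nM in this assay, at which 2 of the 4 values shown sit). Compound 2, with a different aromatic group on the same nitrogen, gives only a limit (> 100000 nM) in this assay.

Open, on these data alone, is whether a longer chain such as phenylethyl, or a chain ending in an amine, would be tolerated on this nitrogen. Also open, as far as these compounds go, is whether any group there could give a clearly lower number than compound 1.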